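From a formyl hydrazide to the free acid

The compounds below may be only part of what the source reports. "The series", "measured", "known", "first", "only" and "open" are said of these compounds alone.

Compound 1 `COc1ccc(C(=O)NNC(=O)c2ccc3[nH]c(-c4ccc([N+](=O)[O-])o4)nc3c2)cc1OC`: 15.6 ug/mL
Compound 2 `O=CNNC(=O)c1ccc2[nH]c(-c3ccc([N+](=O)[O-])o3)nc2c1`: 31.3 ug/mL

Among the measured compounds shown here, in a functional assay on NCI-H460 cells (Homo sapiens) for inhibition, read by sulforhodamine B assay, with a stated time of 48 h (on this read-out higher numbers stand for weaker inhibition of growth and lower numbers for stronger inhibition of growth), compound 2 gives 31.3 ug/mL, and the single step measured so far, a 2.0-fold higher number from compound 1 to compound 2 (0.30 log units; within the scatter), leaves the two measured compounds level with each other. Compound 3 `O=C(O)c1ccc2[nH]c(-c3ccc([N+](=O)[O-])o3)nc2c1` differs from compound 2 in this way: hydroxy in place of (formylamino)amino on a carbonyl carbon. For the measured compounds named here, no measured step touches this kind of change; the one step known concerns a different group and was small. Compound 3 is therefore expected to stay near compound 2, with an estimated step of a 1.3-fold higher number from compound 2 to compound 3 (0.11 log units; within the scatter). The estimate for compound 3 is 40 ug/mL, with a range from 12 ug/mL to 100 ug/mL.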

Compound 3, concentration for 50% growth inhibition: 125 ug/mL
Compound 3: middle estimate off by 3.1-fold (0.49 log units), on the low side; measured number outside the range, above it.
By their numbers in this assay, from the lowest: compounds 1 and 2 (each within the scatter of the next); then compound 3.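

In this assay, hydroxy in place of (formylamino)amino on the carbonyl carbon gives a 4.0-fold higher number from compound 2 to compound 3 (0.60 log units; beyond the scatter), which lies beyond the scatter. The earlier step at this carbonyl carbon, which altered only the far end of the substituent, stayed within the scatter, so this position does respond when the whole (formylamino)amino group is replaced. Nothing available explains this step.

On these data alone, whether the step reflects the loss of (formylamino)amino or the arrival of hydroxy stays open. An amino group or a methoxy group on the same carbonyl carbon would help separate the two.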